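The source may hold more compounds than are shown below. What is called first, only, known or untested is meant among the compounds shown, and "the series" means these compounds.

Measured so far in an ADME assay on microsomes from liver (Homo sapiens) for metabolic stability, tested at 2.5 uM; on this read-out lower numbers stand for slow clearance and higher numbers for fast clearance:

Compound 1 `O=S(=O)(c1cccc(F)c1)c1cnc2cc(F)ccc2c1-c1ccc(F)cc1` gives 0.11 mL/min.
Compound 2 `O=S(=O)(c1ccc(F)cc1)c1cnc2cc(F)ccc2c1-c1ccc(F)cc1` gives 1.34 mL/min.
Compound 3 `COc1ccc(-c2c(S(=O)(=O)c3ccc(F)cc3)cnc3c(F)cccc23)cc1` gives 2.41 mL/min.

One structural change appears twice among these compounds. The first time it is measured: 3-fluorophenyl in place of 4-fluorophenyl on a sulfonyl sulfur brings a 12-fold lower number from compound 2 to compound 1 (1.09 log units; beyond the scatter). How the core of compound 3 differs from that of compound 2 is not broken down here; what their two values show is that compound 3 and compound 2 lie within the scatter of each other. Compound 4 `COc1ccc(-c2c(S(=O)(=O)c3cccc(F)c3)cnc3c(F)cccc23)cc1` carries the same change applied to compound 3: 3-fluorophenyl in place of 4-fluorophenyl on a sulfonyl sulfur, on the same kind of sulfonyl sulfur.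

Going by the values given here, because the single measured example, a 12-fold lower number from compound 2 to compound 1 (1.09 log units; beyond the scatter), is large, a step downward is expected from compound 3, though on a different core it is estimated smaller, at a 4.8-fold lower number from compound 3 to compound 4 (0.68 log units; beyond the scatter). Compound 4 is therefore expected to give about 0.5 mL/min in this assay, estimated between 0.15 mL/min and 1.8 mL/min.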

Compound 4, intrinsic clearance in a liver preparation (reported as CLH), per the amount of preparation that the assay uses: 2.48 mL/min
Compound 4: middle estimate off by 5.0-fold (0.70 log units), on the low side; the whole stated range lies below it.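

In this assay, 3-fluorophenyl in place of 4-fluorophenyl on a sulfonyl sulfur brings a 1.0-fold higher number from compound 3 to compound 4 (0.01 log units; within the scatter), so the large drop seen on the core of compound 2 does not carry over to the core of compound 3. The same change therefore gives clearly different results on these two cores: the same change on two cores in this assay, a 12-fold lower number (1.09 log units; beyond the scatter) from compound 2 to compound 1 and a 1.0-fold higher number (0.01 log units; within the scatter) from compound 3 to compound 4, 13-fold (1.10 log units) apart, beyond the scatter of two such steps

Going by these compounds alone, with only two pairs, this does not show which difference between the cores matters, or how the change would behave on a third core. Also open, as far as these compounds go, is how other groups on the sulfonyl sulfur, such as a plain phenyl or a chlorophenyl, would behave on each core.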